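The source may report more compounds than this note shows. Statements on the series, on what has been measured and on what is new or still open speak of the compounds shown alone.

Compound 1, `COc1cc(OC)c2cc(-c3ccccc3)c(O)nc2c1`, 10000 nM in a functional assay on LoVo cells (Homo sapiens) for cytotoxicity, read by colorimetric assay and MTT assay; on this read-out lower numbers stand for stronger inhibition and higher numbers for weaker inhibition. Compound 2, `COc1ccc(-c2cc3c(OC)ccc(OC)c3nc2O)cc1`, 10000 nM. Compound 3, `COc1ccc(-c2cc3c(OC)cc(OC)cc3n(C)c2=O)cc1`, 10000 nM.

On these numbers compound 3 stands level with compound 1 and with compound 2 at the digits shown; neither gap reaches beyond the scatter of repeated measurements, so no order among the three can be drawn. Compound 4 `COc1ccc(-c2cc3c(OC)cc(OC)cc3n(CC#N)c2=O)cc1` differs from compound 3 by cyano in place of hydrogen on a saturated chain carbon bound to an aromatic nitrogen. Among the compounds with values here, no pair of measured compounds shows the effect of such a change, so the expectation rests on the shared standing of the three. Compound 4 is expected to show no step beyond the scatter, no change at the digits printed from compound 3 to compound 4 (within the scatter). The estimate for compound 4 in this assay is 10000 nM, within a range from 3000 nM to 30000 nM.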

Compound 4, half-maximal inhibitory concentration: 10000 nM
Estimate against measurement, compound 4: no gap at the digits printed; the range from low to high includes it.
By their numbers in this assay, from the lowest: compounds 1, 2, 3 and 4 (each within the scatter of the next).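

In this assay, within the data shown here, the one readable step runs no change at the digits printed from compound 3 to compound 4 (within the scatter) and so gives the only reading of a change at this place, since the earlier compounds offered no pair differing in one place. Methyl to cyanomethyl on the aromatic nitrogen, adding a nitrile, leaves the printed value as it stood. Nothing measured here accounts for this result. The compounds shown leave open whether an amine, a carboxylic acid or a longer chain at this place would give a value beyond the scatter of compound 3.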